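A few compounds are considered here, and "the series" means these few. Any claim that something is new, unique, unknown or untested is made for them only; others in the source may bear on it.

Compound 1 `O=C(Cc1ccccn1)NC1CCN(Cc2ccccc2)CC1` gives 236 nM in an assay on membranes from brain (Cavia porcellus) for binding affinity to Sigma non-opioid intracellular receptor 1 (Homo sapiens), read by radioligand binding; on this read-out higher numbers stand for weaker inhibition and lower numbers for stronger inhibition.
Compound 2 `COc1ccc2c(c1)C(CC(=O)NC1CCN(Cc3ccccc3)CC1)CC2=O` gives 299 nM in this assay.
Compound 3 `O=C(CC1=CC(=O)OC2C=C(O)C=CC12)NC1CCN(Cc2ccccc2)CC1` reaches only a limit, > 1000 nM, in this assay.

Of the two plain numbers, compound 1 carries the lowest, yet compound 2 sits within the usual scatter of it, so the two cannot be told apart. The result for compound 3 is a limit rather than a number, and one of the three values stands there (the limit of > 1000 nM in this assay, at which 1 of the 3 values shown sits).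

Compound 4 `O=C(CSc1ncccn1)NC1CCN(Cc2ccccc2)CC1` differs from compound 1 in one place: (pyrimidin-2-yl)sulfanyl in place of pyridin-2-yl on a saturated chain carbon bound to a carbonyl carbon. Among the measured compounds shown here, no measured pair shows this change, so no step can be borrowed. In this assay the expected step of a 1.4-fold higher number from compound 1 to compound 4 (0.13 log units; within the scatter) is small, toward a somewhat weaker value, hardly beyond the scatter. Compound 4 is therefore estimated at 320 nM, with a range from 100 nM to 1000 nM.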

Compound 4, inhibition constant: 150 nM
Compound 4: the middle estimate sits 2.1-fold (0.33 log units) above what was measured; measured number inside the range.
By their numbers in this assay, from the lowest: compounds 4, 1 and 2 (each within the scatter of the next). At a limit, above all of these: compound 3.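

In this assay, the change from pyridin-2-yl to (pyrimidin-2-yl)sulfanyl gives a 1.6-fold lower number from compound 1 to compound 4 (0.20 log units; within the scatter). This position therefore takes a group with one more heavy atom, a sulfur and a second ring nitrogen, and the two compounds still cannot be told apart. No measurement shown here accounts for this step. Sulfur and the extra ring nitrogen enter together, so their separate contributions remain open. Going by these compounds, what an amine or a carboxylic acid would do at this place is also open.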